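The source may hold more compounds than are shown below. What is called first, only, known or untested is meant among the compounds shown, and "the series" means these compounds.

Measured so far:
- compound 1 `CCc1ccccc1N(CC(=O)NCc1ccc(Cl)cc1)S(=O)(=O)c1ccc(C)cc1`: 10 nM
- compound 2 `Cc1ccc(S(=O)(=O)N(CC(=O)NCc2ccc(Cl)cc2)c2cccc(C)n2)cc1`: < 1000 nM

In an assay on CHO cells for displacement of a labelled ligand from prostaglandin E2 receptor EP1 subtype (Homo sapiens) (on this read-out lower numbers stand for stronger inhibition and higher numbers for weaker inhibition), compound 1 gives 10 nM. Compound 2 is known only by a limit: in this assay compound 2 gives < 1000 nM, a limit of the assay and not a number. The step that the limit leaves unreadable from compound 1 to compound 2 therefore cannot be read, because the limit of < 1000 nM in this assay, at which 1 of the 2 values shown sits, hides where compound 2 actually stands.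

Compound 3 `Cc1ccc(S(=O)(=O)N(CC(=O)NCc2ccc(Cl)cc2)c2ccc(C)cn2)cc1` differs from compound 2 by 5-methylpyridin-2-yl in place of 6-methylpyridin-2-yl on a sulfonamide nitrogen. Within the data shown here, no measured step covers a shift of the methyl group on the pyridine, and the single step that exists, from compound 1 to compound 2, is unreadable, so there is nothing measured that sets the size or direction of this change.

Compound 2 stands at a limit, so any expectation for compound 3 inherits that uncertainty. Compound 3 is expected to give about 300 nM in this assay, with a wide range from 30 nM to 3000 nM. Among the measured compounds shown here, the expected step that the limit leaves unreadable from compound 2 to compound 3 is little more than a placeholder, since compound 2 has no firm number to step from.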

Compound 3, inhibition constant: < 1000 nM
Compound 3: only a limit was reported; the forecaster's own chance of this, stated with the estimate: 40%; the middle value lies beyond the limit too.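

In this assay compound 3 gives < 1000 nM as a limit of the assay and not a number. Among these compounds, no step from compound 1 or compound 2 to compound 3 can be read, because the values stop at a limit: the limit of < 1000 nM in this assay, at which 2 of the 3 values shown sit. Still open, from the compounds shown here alone, is where compound 2 and compound 3 actually stand, and whether 5-methylpyridin-2-yl and 6-methylpyridin-2-yl differ at all.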